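The source may hold more compounds than are shown below. What is called first, only, known or untested is meant among the compounds shown, and "the series" means these compounds.

Working notes on the series.

Three compounds have numbers in a physicochemical assay for solubility, in phosphate buffer, measured as kinetic solubility; a lower number here means a less soluble compound, a higher number a more soluble compound. Compound 1 `CC(C)[C@@H](C[C@H]1SC(=O)NC1=O)c1ccc(-c2ccc3cccc(F)c3c2)[nH]c1=O` gives 23900 nM in this assay. Compound 2 `CC(C)[C@H](C[C@H]1OC(=O)NC1=O)c1ccc(-c2ccc3cccc(F)c3c2)[nH]c1=O` gives 35400 nM. Compound 3 `O=C1NC(=O)/C(=C/C(c2ccc(-c3ccc4cccc(F)c4c3)[nH]c2=O)C2CC2)O1` gives 30800 nM, which is the second highest of the three numbers; its nearest neighbour is compound 2 and the furthest is compound 1, but both gaps lie within the usual scatter of this assay, so the three compounds sit together and no order among them can be read from these numbers.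

Going by the values given here, no pair of measured compounds differs in exactly one place, so no isolated step is available from the measured set.

The next compound is compound 4 `CCC(CC)C(/C=C1\OC(=O)NC1=O)c1ccc(-c2ccc3cccc(F)c3c2)[nH]c1=O`. It differs from compound 3 in one place:

pentan-3-yl in place of cyclopropyl on a saturated chain carbon bound to an aromatic carbon and a double-bonded chain carbon

The exchange on the saturated chain carbon bound to an aromatic carbon and a double-bonded chain carbon is the only difference. Nothing in the measured set shows what this exchange does in this assay. The expectation is a moderate downward step, a 2.1-fold lower number from compound 3 to compound 4 (0.31 log units; beyond the scatter), on the understanding that the move may also fall inside the scatter. The solubility of compound 4 in this assay is estimated at 15000 nM, with a range from 6000 nM to 35000 nM.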

Compound 4, solubility: 33700 nM
The estimate for compound 4 lay 2.2-fold (0.35 log units) below the measured number, and the stated range covers the measured number.
By their numbers in this assay, from the lowest: compounds 1, 3, 4 and 2 (each within the scatter of the next).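

In this assay, going by these compounds alone, the exchange of cyclopropyl for pentan-3-yl on a saturated chain carbon bound to an aromatic carbon and a double-bonded chain carbon gives a 1.1-fold higher number from compound 3 to compound 4 (0.04 log units; within the scatter), the first isolated step at this position, and it cannot be told from repeat scatter. At this place an open group of 5 carbon atoms therefore stands in for a three-membered carbon ring of 3 carbon atoms with no readable move in the number, so neither the loss of the ring nor the added heavy atoms shows up as a separate result in this pair. No measurement at hand offers an explanation for this flat step.

On these data alone, both groups compared at this position are carbon only and carry no hydrogen-bond donors or acceptors, so it stays open whether a group bearing an amine, a hydroxyl or a carboxylic acid at the same place would shift the number beyond the scatter. As far as these compounds go, compound 1 and compound 2 differ from compound 3 and compound 4 in more than one place, so what the rest of the chain contributes stays open as well.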